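A Longer Alkyl Chain on the Carbamate Ester

The source may report more compounds than this note shows. Statements on the series, on what has been measured and on what is new or still open speak of the compounds shown alone.

Compound 1 `COc1ccc(OC(=O)Nc2ccc([Se]C#N)cc2)cc1`: 69600 nM
Compound 2 `CC(C)COC(=O)Nc1ccc([Se]C#N)cc1`: 63700 nM
Compound 3 `CCCCCCOC(=O)Nc1ccc([Se][Se]c2ccc(NC(=O)OCCCCCC)cc2)cc1`: 74200 nM

These three compounds were tested in a functional assay on HT-29 cells (Homo sapiens) for cytotoxicity, read by MTT assay, with a stated time of 72 h; a lower number here means that less compound is tolerated, a higher number that more compound is tolerated. Compound 2 gives 63700 nM, and the numbers for compound 1 and compound 3 lie so close to it that none of the three is separated from another by more than the usual scatter of repeated measurements. Compound 4 `CCCCCCOC(=O)Nc1ccc([Se]C#N)cc1` has not yet been measured. It differs from compound 2 in one place: pentyl in place of isopropyl on a saturated chain carbon bound to an oxygen next to a carbonyl group. Going by the values given here, no measured pair in this set differs in only one place, so no measured step is available to guide the expectation; the three measured numbers are simply alike. The step of a 1.1-fold higher number from compound 2 to compound 4 (0.03 log units; within the scatter) is therefore expected to stay within the scatter. Compound 4 is estimated at 68000 nM, within 35000 nM to 130000 nM.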

Compound 4, concentration lethal to 50% of the cells: 69900 nM
Estimate against measurement, compound 4: 1.0-fold (0.01 log units) below; low and high end bracket the measured number.
By their numbers in this assay, from the lowest: compounds 2, 1, 4 and 3 (each within the scatter of the next).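

Going by these compounds alone, this is the first step in the set that alters a single place, and in this assay pentyl in place of isopropyl on a saturated chain carbon bound to an oxygen next to a carbonyl group gives a 1.1-fold higher number from compound 2 to compound 4 (0.04 log units; within the scatter) and nothing more. At this position, then, the two chains cannot be told apart in this read-out. No measurement here offers an explanation for this.

In this assay, going by these compounds, it stays open whether a longer chain, an amine or a carboxylic acid in this place would move the number beyond the scatter. Whether these two compounds also stay alike on other cell types is open too.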